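A few compounds are considered here, and "the series" means these few. Any claim that something is new, unique, unknown or untested is made for them only; others in the source may bear on it.

In a functional assay on HCT-116 cells (Homo sapiens), read by MTT assay, with a stated time of 72 h (on this read-out higher numbers stand for weaker inhibition and lower numbers for stronger inhibition), compound 1 `Cc1ncnc2c1c(-c1ccoc1)cn2[C@@H]1O[C@H](CO)[C@@H](O)[C@H]1O` gives > 20000 nM, which is a limit of the assay rather than a number. Compound 2 `Cc1ncnc2c1c(-c1cc3ccccc3o1)cn2[C@@H]1O[C@H](CO)[C@@H](O)[C@H]1O` also sits at a limit, > 20000 nM. Compound 3 `Cc1nc(N)c2c(-c3ccoc3)cn([C@@H]3O[C@H](CO)[C@@H](O)[C@H]3O)c2n1` likewise reaches only a limit, > 20000 nM. So far the series stands at the limit of > 20000 nM in this assay, at which 3 of the 3 values shown sit. Compound 4 `C#Cc1cn([C@@H]2O[C@H](CO)[C@@H](O)[C@H]2O)c2nc(C)nc(N)c12` carries ethynyl in place of furan-3-yl on an aromatic carbon. Among the measured compounds shown here, the only step between measured compounds that bears on this change, a step that the two limits leave unreadable from compound 1 to compound 2, offers no size to carry over. Weak inhibition is therefore still expected, with any shift more likely towards stronger inhibition. The expected change is an at least 1.3-fold lower number from compound 3 to compound 4 (0.12 log units; that floor lies within the scatter), a rough estimate. For compound 4 the estimated value is 15000 nM, with an expected range from 2000 nM to 30000 nM.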

Compound 4, half-maximal inhibitory concentration: > 20000 nM
Compound 4 ended at the assay's limit; the forecaster's own chance of this, stated with the estimate: 60%; middle value at least 1.3-fold (0.12 log units) away from the limit.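

In this assay, among the compounds shown here, compound 3 and compound 4 both end at a limit rather than a number, so no step between them can be read. The compounds shown leave open which structural change, if any, brings measurable inhibition, as all of them stop at the same limit: the limit of > 20000 nM in this assay, at which 4 of the 4 values shown sit.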